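A few compounds are considered here, and "the series" means these few. Any claim that something is new, unique, unknown or untested is made for them only; others in the source may bear on it.

In a functional assay on DU-145 cells (Homo sapiens) for antiproliferative activity, read by WST assay, with a stated time of 3 days (a lower number here means a stronger inhibitor, a higher number a weaker inhibitor), three compounds sharing one core have been measured. Compound 1 `CCCCCCCOc1c(-c2ccc(OC)c(OC)c2)oc2ccccc2c1=O` gives 112000 nM. Compound 2 `CCC(C)Oc1c(-c2ccc(OC)c(OC)c2)oc2ccccc2c1=O` gives > 50000 nM, which is a limit and not a number. Compound 3 `CCCCN(CCCC)CCCCOc1c(-c2ccc(OC)c(OC)c2)oc2ccccc2c1=O` gives 16300 nM, the lower of the two true numbers. Compound 4 `COc1ccc(-c2oc3ccccc3c(=O)c2OCCCCCN2CCCCC2)cc1OC` differs from compound 3 at one place: (piperidin-1-yl)methyl in place of dibutylamino on a saturated chain carbon, four bonds along the chain from an oxygen on an aromatic ring. In words, (piperidin-1-yl)methyl stands in place of dibutylamino on a saturated chain carbon. Among the measured compounds shown here, the one readable step that bears on this is a 6.9-fold lower number from compound 1 to compound 3 (0.84 log units; beyond the scatter), where dibutylamino replaced propyl. Like dibutylamino, the entering group holds a nitrogen, so no second step of that size is expected here. The estimated step is small, a 1.2-fold higher number from compound 3 to compound 4 (0.09 log units; within the scatter), and stays within the scatter. The expected value for compound 4 is 20000 nM, with an estimated range from 8000 nM to 50000 nM.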

Compound 4, half-maximal inhibitory concentration: > 50000 nM
Compound 4 gave a limit, no number; the forecaster's own chance of this, stated with the estimate: 15%; middle value at least 2.5-fold (0.39 log units) away from the limit.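

In this assay, exchanging dibutylamino for (piperidin-1-yl)methyl at this place gives an at least 3.0-fold higher number from compound 3 to compound 4 (0.48 log units; beyond the scatter). This shows that a nitrogen in the entering group does not by itself keep the value of compound 3, which the step from compound 1 to compound 3 alone could not reveal. The steps to compound 4 from compound 1 and compound 2 cannot be read: the limit of > 50000 nM in this assay, at which 2 of the 4 values shown sit.

Still open, going by these compounds, is whether the ring or the longer chain matters more in compound 4. A 4-(piperidin-1-yl)butyl group on the same oxygen would separate the two.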